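The compounds below may be only part of what the source reports. "The series", "measured", "known", "first", "only" and "open" are said of these compounds alone.

Working notes on the series in a functional assay on CCRF-CEM cells (Homo sapiens) for cytotoxicity, in the absence of a further agent; a lower number here means a stronger inhibitor, a higher number a weaker inhibitor. Compound 1 `COC(=O)c1ccc(CN(CCCc2c(N)nc(N)nc2O)c2cc(F)c(F)cc2[N+](=O)[O-])cc1` gives 66000 nM, and compound 3 `COC(=O)c1ccc(CN(CCCc2c(N)nc(N)nc2O)c2ccc([N+](=O)[O-])c(F)c2F)cc1` gives 55000 nM. Among the compounds with values here, these are the only two numbers in the set, and they lie within the scatter of each other. Compound 2 `Nc1nc(N)c(CCCN(Cc2ccc(NC(CCC(=O)O)C(=O)O)cc2)c2cc(F)ccc2[N+](=O)[O-])c(O)n1` gives > 100000 nM, which is a limit of the assay and not a number. For the upper end of any estimate, the relevant ceiling is the limit of > 100000 nM in this assay, at which 1 of the 3 values shown sits.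

Compound 4 `COC(=O)c1ccc(CN(CCCc2c(N)nc(N)nc2O)c2cc(F)ccc2[N+](=O)[O-])cc1` has not been measured. Relative to compound 3, it carries 5-fluoro-2-nitrophenyl in place of 2,3-difluoro-4-nitrophenyl on an amine nitrogen.

Within the data shown here, one measured step bears on this change, an exchange of the aryl group at the same place: a 1.2-fold lower number from compound 1 to compound 3 (0.08 log units; within the scatter). That step lies within the scatter, so no step beyond the scatter is expected in this assay, in either direction. The expected step is a 1.1-fold higher number from compound 3 to compound 4 (0.04 log units; within the scatter).

For compound 4 the estimated value is 60000 nM, with an expected range of 30000 nM to 100000 nM.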

Compound 4, half-maximal inhibitory concentration: 55000 nM
Compound 4: middle estimate off by 1.1-fold (0.04 log units), on the high side, and the stated range covers the measured number.
By their numbers in this assay, from the lowest: compounds 3, 4 and 1 (each within the scatter of the next). At a limit, above all of these: compound 2.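

In this assay, the third aryl group on this amine nitrogen again cannot be told apart from the others: 5-fluoro-2-nitrophenyl in place of 2,3-difluoro-4-nitrophenyl gives no change at the digits printed from compound 3 to compound 4 (within the scatter), and hydrogen in place of fluoro on an aromatic carbon gives a 1.2-fold lower number from compound 1 to compound 4 (0.08 log units; within the scatter). Across compounds 1, 3 and 4, neither the number of fluoro groups nor the choice among these three aryl groups separates the values. Compound 4 also gives the first single-place comparison with compound 2, whose value is a limit of the assay, so methoxycarbonyl in place of (1,3-dicarboxypropyl)amino gives only a floor, an at least 1.8-fold lower number from compound 2 to compound 4 (0.25 log units; that floor lies within the scatter): the limit of > 100000 nM in this assay, at which 1 of the 4 values shown sits.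

From the compounds shown here alone, it remains open whether an aryl group carrying a nitrile or trifluoromethyl instead of nitro, or a plain phenyl, would shift the number beyond the scatter. A lone carboxylic acid in place of methoxycarbonyl on that aromatic carbon is also unresolved.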